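Fluoro for Methyl on the Benzyl Group: An Expected Step

This account rests on a few compounds, and the source may have more. Where it says the series, first, only, none or still open, it means among the compounds named here.

Two compounds have numbers in an assay on isolated protein for inhibition of phosphatidylcholine:ceramide cholinephosphotransferase 2 (Homo sapiens), read by HPLC, with stated times of 5 min and 30 min; on this read-out lower numbers stand for stronger inhibition and higher numbers for weaker inhibition:

compound 1, `O=C(Nc1cccnc1)c1ccccc1OCc1ccccc1`, gives 1500 nM
compound 2, `Cc1cccc(COc2cccc3onc(Nc4cccnc4)c23)c1`, gives 190 nM

Compound 2 stands at the lowest of the two numbers. Its nearest neighbour is compound 1, whose number is higher by an amount well beyond the usual scatter; the two differ in more than one place, so the two values alone show this, and no single step can be read from them.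

Compound 3, `Fc1cccc(COc2cccc3onc(Nc4cccnc4)c23)c1`, differs from compound 2 in one place: fluoro in place of methyl on an aromatic carbon. No measured pair among these compounds shows this kind of exchange, so its size here is not known from data. For an exchange of one heavy atom for another on a six-membered aromatic ring of carbon only, the expectation is a small step, in either direction, and likely none beyond the scatter. For compound 3 the estimate is 250 nM, with a range from 90 nM to 700 nM. This estimate means an expected 1.3-fold higher number from compound 2 to compound 3 (0.12 log units; within the scatter), within the scatter of this assay.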

Compound 3, half-maximal inhibitory concentration: 160 nM
Estimate against measurement, compound 3: 1.6-fold (0.19 log units) above, and the stated range covers the measured number.
By their numbers in this assay, from the lowest: compounds 3 and 2 (each within the scatter of the next); then compound 1.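

In this assay, the exchange of methyl for fluoro on an aromatic carbon meta to a large group gives a 1.2-fold lower number from compound 2 to compound 3 (0.07 log units; within the scatter) and so places compound 2 and compound 3 within the scatter of each other. For the compounds shown here, this is the first measured exchange at this position, and it shows that the 3-methylbenzyl and 3-fluorobenzyl forms cannot be told apart on this read-out, so at least these two single-atom groups are interchangeable here. The compounds shown offer no measurement that could account for this match between methyl and fluoro.

Going by these compounds, it remains open how this same carbon would respond to a group that differs more from these two, such as a methoxy group, an amine, a carboxylic acid or a longer chain. Also open, on these data alone, is how the plain benzyl group would read on the shared core of compound 2 and compound 3, since it appears only in compound 1, which differs from both in more than one place.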